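Extending the pentyl chain of compound 3

This account rests on a few compounds, and the source may have more. Where it says the series, first, only, none or still open, it means among the compounds named here.

Of the compounds shown here, three with a shared core have been measured in a functional assay on A549 cells (Homo sapiens) for antiproliferative activity, read by MTT assay; a lower number here means a stronger inhibitor, a higher number a weaker inhibitor. Compound 1 `CC1(C)CCc2cc(C(=O)/C=C/c3ccc(OCc4cn(-c5ccc(Br)cc5)nn4)cc3)c(O)cc2O1`, which carries 4-bromophenyl on an aromatic nitrogen, gives 80000 nM. Compound 2 `CC(=O)c1ccc(-n2cc(COc3ccc(/C=C/C(=O)c4cc5c(cc4O)OC(C)(C)CC5)cc3)nn2)cc1`, with 4-acetylphenyl at that nitrogen, gives 66300 nM. Compound 3 `CCCCCn1cc(COc2ccc(/C=C/C(=O)c3cc4c(cc3O)OC(C)(C)CC4)cc2)nn1`, with pentyl there, gives 91300 nM, which places it level with the other two, within the scatter of each.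

Compound 4 `CCCCCCCCn1cc(COc2ccc(/C=C/C(=O)c3cc4c(cc3O)OC(C)(C)CC4)cc2)nn1` has not yet been measured. Its structure departs from that of compound 3 by propyl in place of hydrogen on a saturated chain carbon, five bonds along the chain from an aromatic nitrogen. Among the measured compounds shown here, no measured step changes the length of a chain, so the evidence is indirect. Replacing 4-bromophenyl with pentyl gives a 1.1-fold higher number from compound 1 to compound 3 (0.06 log units; within the scatter), and replacing 4-acetylphenyl with pentyl gives a 1.4-fold higher number from compound 2 to compound 3 (0.14 log units; within the scatter). Acetyl in place of bromo gives a 1.2-fold lower number from compound 1 to compound 2 (0.08 log units; within the scatter). All three steps stay within the scatter, even though the group on that nitrogen differs considerably, and so no change beyond the scatter is expected here. The expected step is a 1.2-fold lower number from compound 3 to compound 4 (0.09 log units; within the scatter). For compound 4 the estimated value is 75000 nM, with an expected range of 35000 nM to 130000 nM.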

Compound 4, half-maximal inhibitory concentration: 50800 nM
The estimate for compound 4 lay 1.5-fold (0.17 log units) above the measured number; measured number inside the range.
By their numbers in this assay, from the lowest: compounds 4, 2, 1 and 3 (each within the scatter of the next).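

Among the compounds shown here, compound 4 gives the first direct reading of chain length on the aromatic nitrogen in this assay: taking pentyl out to octyl, with propyl in place of hydrogen on a saturated chain carbon, five bonds along the chain from an aromatic nitrogen, gives a 1.8-fold lower number from compound 3 to compound 4 (0.25 log units; within the scatter) and so leaves the number within the scatter. Octyl also stands level with the two substituted phenyl groups, with a 1.3-fold lower number from compound 2 to compound 4 (0.12 log units; within the scatter) against 4-acetylphenyl and a 1.6-fold lower number from compound 1 to compound 4 (0.20 log units; within the scatter) against 4-bromophenyl. Across these four compounds, then, neither lengthening the saturated chain nor exchanging it for either substituted phenyl group gives a step beyond the scatter, and no evidence here offers an explanation for this result.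

The compounds shown leave open whether a chain longer than octyl, or a shorter one such as propyl, would stay level with these four. They also leave open whether an amine or a carboxylic acid at the end of the chain would give a step beyond the scatter.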